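Methyl in place of methoxy on compound 1

This account rests on a few compounds, and the source may have more. Where it says the series, first, only, none or still open, it means among the compounds named here.

In a functional assay on HeLa cells (Homo sapiens) for antiproliferative activity, with a stated time of 5 days (a higher number here means a weaker inhibitor, a lower number a stronger inhibitor), compound 1 (`COc1ccc(-n2nc(-c3ccc4ccccc4c3)nc2N2C(=O)COC23C=CC(=O)C=C3)cc1`) gives 200 nM. Compound 2 (`CC1OC2(C=CC(=O)C=C2)N(c2nc(-c3ccc4ccccc4c3)nn2-c2ccc3ccccc3c2)C1=O`) gives 300 nM and compound 3 (`O=C1C=CC2(C=C1)OCC(=O)N2c1nc(-c2ccc3ncccc3c2)nn1-c1ccccc1`) gives 110 nM, and compound 1 lies within the scatter of both. Compound 4 (`Cc1ccc(-n2nc(-c3ccc4ccccc4c3)nc2N2C(=O)COC23C=CC(=O)C=C3)cc1`) carries methyl in place of methoxy on an aromatic carbon, para to a large group, so 4-methoxyphenyl becomes 4-methylphenyl (methyl in place of methoxy on an aromatic carbon). For the measured compounds named here, no measured pair of compounds shows this change on its own, so the data offer no direct guide to it. In this assay, no step beyond the scatter is expected, and no direction is favoured. The expected move is no change at the digits printed from compound 1 to compound 4 (within the scatter). For compound 4 the estimated value is 200 nM, with an expected range from 80 nM to 500 nM.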

Compound 4, half-maximal inhibitory concentration: 150 nM
The estimate for compound 4 lay 1.3-fold (0.12 log units) above the measured number; the range from low to high includes it.
By their numbers in this assay, from the lowest: compounds 3, 4, 1 and 2 (each within the scatter of the next, the first and the last beyond it).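

In this assay, for the compounds shown here, the first direct reading of a change at this position is a 1.3-fold lower number from compound 1 to compound 4 (0.12 log units; within the scatter) and so lies within the scatter. On this aromatic carbon, para to a large group, methyl can therefore stand in place of methoxy, with one hydrogen-bond acceptor fewer by the count, without a step beyond the scatter. No measurement on hand accounts for this result. From the compounds shown here alone, whether a carboxylic acid or an amine on the same carbon would also stay within the scatter remains open, as does whether this exchange reads the same on another core.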